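Compound 3: a step that starts from a limit

A few compounds are considered here, and "the series" means these few. Any claim that something is new, unique, unknown or untested is made for them only; others in the source may bear on it.

Compound 1 `COc1cc(COc2ccc(C(=O)N/N=C/c3cc(Br)cc(Cl)c3O)cc2)cc(OC)c1OC`: > 100 ug/mL, a limit
Compound 2 `COc1cc(COc2ccc(C(=O)N/N=C/c3ccc(OC)c(OC)c3OC)cc2)cc(OC)c1OC`: > 100 ug/mL, a limit

Both entries come from a physicochemical assay, with a stated time of 30 min; on this read-out lower numbers stand for stronger inhibition and higher numbers for weaker inhibition. Compound 1 stands at > 100 ug/mL, which is a limit of the assay and not a number.

Compound 3 `COc1cc(COc2ccc(C(=O)N/N=C/c3cccc(O)c3)cc2)cc(OC)c1OC` keeps the core of compound 1 and changes one group: 3-hydroxyphenyl in place of 5-bromo-3-chloro-2-hydroxyphenyl on a carbon with a double bond to nitrogen. For the measured compounds named here, the only measured step that bears on this change is a step that the two limits leave unreadable from compound 1 to compound 2, which replaces the same group. Its size cannot be read, and the data show (the limit of > 100 ug/mL in this assay, at which 2 of the 2 values shown sit). So no measured compound offers a number to start from, and no step of known size is available as a guide.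

The expected step, a step that the limit leaves unreadable from compound 1 to compound 3, is no clear move towards stronger inhibition. Compound 3 is estimated at 150 ug/mL, with an expected range of 60 ug/mL to 400 ug/mL.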

Compound 3, half-maximal inhibitory concentration: > 100 ug/mL
Compound 3 gave a limit, no number; the forecaster's own chance of this, stated with the estimate: 75%; the middle value lies beyond the limit too.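

Compound 3 gives only a limit, not a number, so its steps from compound 1 and compound 2 cannot be read: the limit of > 100 ug/mL in this assay, at which 3 of the 3 values shown sit.

The compounds shown leave open how strongly any of them inhibits in this assay, and whether changing this one group alters that inhibition at all.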